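The source may report more compounds than this note shows. Statements on the series, on what has been measured and on what is new or still open speak of the compounds shown alone.

Compound 1, `COC(=O)c1c(-c2ccc([N+](=O)[O-])cc2)oc2ccccc2c1=O`: in a functional assay on SK-MEL cells (Homo sapiens) for cytotoxicity, read by MTT assay, with a stated time of 6 days (a higher number here means that more compound is needed for the effect, a lower number that less compound is needed), compound 1 gives > 25 ug/mL, a limit of the assay rather than a number.
Compound 2, `COC(=O)c1c(-c2ccc([N+](=O)[O-])cc2)oc2cc(OC)ccc2c1=O`: in this assay compound 2 gives 2.84 ug/mL.
Compound 3, `COc1ccc2c(=O)cc(-c3cc(OC)c(OC)c(OC)c3)oc2c1`: in this assay compound 3 gives > 25 ug/mL, again a limit and not a number.

Two of the three measured values sit at a limit, as the record shows: the limit of > 25 ug/mL in this assay, at which 2 of the 3 values shown sit. Among the measured compounds shown here, the one measured step is therefore itself only a bound: an at least 8.8-fold lower number from compound 1 to compound 2 (0.94 log units; beyond the scatter). The change behind it is methoxy in place of hydrogen on an aromatic carbon.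

Compound 4, `COc1cc(-c2cc(=O)c3ccc(OC)c(OC)c3o2)cc(OC)c1OC`, has not yet been measured in this assay. It arises from compound 3 by methoxy in place of hydrogen on an aromatic carbon. For the measured compounds named here, this is the same kind of change as the one from compound 1 to compound 2, but not the same: in the earlier case the new group sits meta to a fused ring and para to a fused ring, whereas here it sits ortho to a fused ring, ortho to a methoxy group and meta to a fused ring. How the core of compound 3 differs from the core of compound 1 is not broken down here.

Because compound 3 gives only > 25 ug/mL in this assay, the starting point for compound 4 is a bound, not a number, and the earlier step offers only a direction. Compound 4 is expected to show an at least 1.6-fold lower number from compound 3 to compound 4 (0.22 log units; that floor lies within the scatter). Compound 4 is estimated at 15 ug/mL, most likely between 4 ug/mL and 50 ug/mL, with a fair chance that only a limit is reported.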

Compound 4, concentration for half-maximal effect: > 25 ug/mL
Compound 4 was reported as a limit; the forecaster's own chance of this, stated with the estimate: 55%; middle value at least 1.6-fold (0.22 log units) from the limit.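

No step can be read from compound 3 to compound 4, since both stop at the same limit, which hides any effect of the added methoxy: the limit of > 25 ug/mL in this assay, at which 3 of the 4 values shown sit.

Left open is whether methoxy in place of hydrogen at this place changes the number in this assay at all, and whether the lower number seen for compound 2 against compound 1 carries over to the core of compound 3.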